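The compounds below may be only part of what the source reports. "The series", "measured", "known", "first", "only" and "open" are said of these compounds alone.

Compound 1 `C=CC1=C(C(=O)NCCC)C(c2ccc(Cl)c(Cl)c2)OC1`: in a functional assay on QGY7701 cells (Homo sapiens) for cytotoxicity, read by MTT assay, with a stated time of 24 h (a higher number here means a weaker inhibitor, a lower number a stronger inhibitor), compound 1 gives 31300 nM.
Compound 2 `C=CC1=C(C(=O)NCC(C)C)C(c2ccc(Cl)c(Cl)c2)OC1`: in this assay compound 2 gives only a limit, > 100000 nM.
Compound 3 `C=CC1=C(C(=O)Nc2ccc(C)cc2)C(c2ccc(F)cc2)OC1`: in this assay compound 3 gives 59200 nM.

Compound 2 thus stands at the limit of this assay (the limit of > 100000 nM in this assay, at which 1 of the 3 values shown sits), with no number of its own. Among the measured compounds shown here, the one measured step, an at least 3.1-fold higher number from compound 1 to compound 2 (0.50 log units; beyond the scatter), concerns a different place than the change now considered. Compound 4 `C=CC1=C(C(=O)NCc2ccccc2)C(c2ccc(Cl)c(Cl)c2)OC1` differs from compound 2 by phenyl in place of isopropyl on a saturated chain carbon bound to an amide-type nitrogen. For the measured compounds named here, no measured step bears directly on this change, so no direction beyond the scatter can be expected with confidence. Compound 4 is estimated at 60000 nM, within 20000 nM to 150000 nM, which would be an expected step of an at least 1.6-fold lower number from compound 2 to compound 4 (0.22 log units; that floor lies within the scatter), with a fair chance that only a limit is again reported.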

Compound 4, half-maximal inhibitory concentration: > 100000 nM
Compound 4: no number, only a limit; the forecaster's own chance of this, stated with the estimate: 40%; middle value at least 1.6-fold (0.22 log units) away from the limit.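

In this assay compound 4 gives only a limit, > 100000 nM, and the step from compound 2, between two limits, cannot be read. Phenyl in place of ethyl on a saturated chain carbon bound to an amide-type nitrogen gives an at least 3.1-fold higher number from compound 1 to compound 4 (0.50 log units; beyond the scatter), so the phenyl of compound 4, like the isopropyl of compound 2, leaves a higher number than compound 1. Compound 2 and compound 4 now sit together at one limit: the limit of > 100000 nM in this assay, at which 2 of the 4 values shown sit.

From the compounds shown here alone, how compound 2 and compound 4 rank remains open. So does what a longer straight chain, a hydroxyl or an amine would give at this place.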